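The source may hold more compounds than are shown below. What is called first, only, known or untested is meant among the compounds shown, and "the series" means these compounds.

Compound 1 `CCCCCCN1CCC(C(=O)Nc2cc(Cl)c(N)cc2OC)CC1`: > 10 mg/kg
Compound 2 `COc1cc(N)c(Cl)cc1NC(=O)C1CCN(CC2CC2)CC1`: > 10 mg/kg

In a functional assay on the whole organism for antagonist activity, with Mus musculus as the target (on this read-out higher numbers stand for an effect only at larger amounts of compound and lower numbers for an effect already at smaller amounts), compound 1 reaches only the limit of the test, > 10 mg/kg. Compound 2 likewise gives only the limit > 10 mg/kg in this assay. So compound 2 stands at the limit of > 10 mg/kg in this assay, at which 2 of the 2 values shown sit, and the one change measured so far, a step that the two limits leave unreadable from compound 1 to compound 2, cannot be sized from two limits. Compound 3 `COc1cc(N)c(Cl)cc1NC(=O)C1CCN(CC2CCCC2)CC1` differs from compound 2 by cyclopentyl in place of cyclopropyl on a saturated chain carbon bound to an amine nitrogen in a ring. Among the compounds with values here, no measured step bears on this change, and both measured values are limits, so nothing sets a direction or a size. Compound 3 is therefore expected to stay near the same limit, an estimated 15 mg/kg within 4 mg/kg to 60 mg/kg. The expected step is thus a step that the limit leaves unreadable from compound 2 to compound 3.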

Compound 3, dose for half-maximal effect: > 10 mg/kg
Compound 3: only a limit was reported (the forecaster's own chance of this, stated with the estimate: 70%); the middle value does not contradict the limit.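

No step can be read among compound 1, compound 2 and compound 3, since each gives only a limit in this assay: the limit of > 10 mg/kg in this assay, at which 3 of the 3 values shown sit.

The compounds shown leave open what dose each one needs for half-maximal effect, and whether swapping pentyl, cyclopropyl and cyclopentyl changes it at all.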